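Swapping the Aromatic Amide Head of a Weak Inhibitor

A few compounds are considered here, and "the series" means these few. Any claim that something is new, unique, unknown or untested is made for them only; others in the source may bear on it.

Among the compounds with values here, compound 1 `Cc1cnc(C(=O)Nc2cc(OCCC3CCN(C(=O)OC(C)(C)C)CC3)cc3cccnc23)cn1` is the only compound here with a number rather than a limit: in a functional assay on PANC-1 cells (Homo sapiens) for inhibition, read by MTT assay, with a stated time of 72 h (on this read-out higher numbers stand for weaker inhibition and lower numbers for stronger inhibition), compound 1 gives 9670 nM. Compound 2 `Cc1cnc(C(=O)Nc2cc(OCCC3CCNCC3)cc3cccnc23)cn1` gives only the limit > 10000 nM in this assay. The step of an at least 1.0-fold higher number from compound 1 to compound 2 (0.01 log units; that floor lies within the scatter) concerns hydrogen in place of tert-butoxycarbonyl, a different place from the change to compound 3 `CC(C)(C)OC(=O)N1CCC(CCOc2cc(NC(=O)c3ncccn3)c3ncccc3c2)CC1`, which is pyrimidin-2-yl in place of 5-methylpyrazin-2-yl on a carbonyl carbon. Within the data shown here, no measured step touches the carbonyl carbon, so the expectation rests on compound 1 alone, with no step beyond the scatter assumed. Compound 3 is estimated at 11000 nM, between 4000 nM and 30000 nM. That expected step is a 1.1-fold higher number from compound 1 to compound 3 (0.06 log units; within the scatter).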

Compound 3, half-maximal inhibitory concentration: > 10000 nM
Compound 3 gave a limit, no number; the forecaster's own chance of this, stated with the estimate: 50%; the middle value is on the limit's open side.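

Within the data shown here, putting pyrimidin-2-yl in place of 5-methylpyrazin-2-yl on the carbonyl carbon gives an at least 1.0-fold higher number from compound 1 to compound 3 (0.01 log units; that floor lies within the scatter), the first reading for a change at this position in this assay. As far as these compounds go, compound 3 gives a limit, > 10000 nM, not a number, so this swap shows no sign of stronger inhibition, while the true size of the step stays unknown. The floor of the range now holds more of the series: the limit of > 10000 nM in this assay, at which 2 of the 3 values shown sit.

From the compounds shown here alone, whether an aromatic head carrying an amine or a carboxylic acid would give a measurable value remains open. So does whether any change at this position can strengthen inhibition.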